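The source may report more compounds than this note shows. Statements on the series, on what has been measured and on what is new or still open speak of the compounds shown alone.

Compound 1 `COc1cc(/C=C/C(=O)c2cccc(NC(=O)c3ccc(Cl)c(Cl)c3)c2)ccc1O`: 5%
Compound 2 `COc1cc(/C=C/C(=O)c2cccc(NC(=O)c3ccco3)c2)ccc1O`: 82%
Compound 3 `COc1cc(/C=C/C(=O)c2cccc(N)c2)ccc1O`: 50%

Of the compounds shown here, three built on one shared core have been measured in a functional assay on HUVEC cells (Homo sapiens) for inhibition, tested at 5 ug/mL; a higher number here means a stronger effect of the compound at the concentration tested, a lower number a weaker effect. Compound 3 gives 50%, the second highest of the three numbers: it stands above compound 1, as a number 45 percentage points higher from compound 1 to compound 3 (beyond the scatter) shows, and below compound 2, as a number 32 percentage points lower from compound 2 to compound 3 (beyond the scatter) shows. Compound 4 `COc1cc(/C=C/C(=O)c2cccc(NC(=O)C(C)C)c2)ccc1O` differs from compound 3 in one place: isopropylcarbonyl in place of hydrogen on a nitrogen on an aromatic ring.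

Among the compounds with values here, two measured steps bear on this change, since each of them also exchanges a hydrogen on that nitrogen for a carbonyl-bearing group, yet they point in opposite directions: a number 45 percentage points higher from compound 1 to compound 3 (beyond the scatter), while a number 32 percentage points lower from compound 2 to compound 3 (beyond the scatter). Whether the isopropylcarbonyl group behaves more like one or the other cannot be told from these three compounds, so a step of moderate size in either direction, or none beyond the scatter, is conceivable. Compound 4 is therefore estimated at 55%, expected to fall between 25% and 85%. This estimate means that a number 5 percentage points higher from compound 3 to compound 4 (within the scatter) is expected.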

Compound 4, a percentage reported as inhibition, at one concentration (the size of the read-out at that concentration, not a potency): 51%
For compound 4 the middle estimate is 4 percentage points above the measured one, and the stated range covers the measured number.
By their numbers in this assay, from the lowest: compound 1; then compounds 3 and 4 (each within the scatter of the next); then compound 2.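

Capping the amino nitrogen with isopropylcarbonyl leaves the number in this assay where it was (a number 1 percentage points higher from compound 3 to compound 4 (within the scatter)), so forming an amide at this position does not by itself separate these compounds. What separates them is the group on the carbonyl carbon: isopropyl in place of furan-2-yl gives a clear drop (a number 31 percentage points lower from compound 2 to compound 4 (beyond the scatter)), while isopropyl in place of 3,4-dichlorophenyl gives a clear rise (a number 46 percentage points higher from compound 1 to compound 4 (beyond the scatter)). Among these amides, compound 4 stays level with the free amine compound 3, while compound 2 lies above that level and compound 1 below it.

Going by these compounds, whether a longer chain or a carboxylic acid on the carbonyl carbon would stay level with isopropyl remains open. Nothing available explains why these groups differ.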